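Carbamate Side-Chain Swap on Two Related Fluorinated Nucleoside Cores

The source may report more compounds than this note shows. Statements on the series, on what has been measured and on what is new or still open speak of the compounds shown alone.

The study compares four compounds that share a fluorinated, carbamate-bearing aromatic unit and differ in the carbamate side chain and in the sugar-like portion. Compound 1, `CCC(C)COC(=O)Nc1nc(=O)n([C@@H]2O[C@H](C)[C@H]3OC(=O)O[C@H]32)cc1F`, and compound 3, `CC(C)CCOC(=O)Nc1nc(=O)n([C@@H]2O[C@H](C)[C@H]3OC(=O)O[C@H]32)cc1F`, carry one core; compound 2, `CCC(C)COC(=O)Nc1nc(=O)n([C@@H]2O[C@H](C)[C@@H](O)[C@H]2O)cc1F`, and compound 4, `CC(C)CCOC(=O)Nc1nc(=O)n([C@@H]2O[C@H](C)[C@@H](O)[C@H]2O)cc1F`, carry the other. How the core of compound 2 differs from the core of compound 1 is not broken down here.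

In a functional assay on NCI-H69 cells (Homo sapiens) for cytotoxicity, read by MTT assay, with a stated time of 3 days (on this read-out higher numbers stand for weaker inhibition and lower numbers for stronger inhibition), compound 1 gives 330 ug/mL, compound 3 gives 310 ug/mL, and compound 2 gives 370 ug/mL. All three numbers lie within the scatter of one another, so no ordering among them can be drawn.

Within the first core, the only change from compound 1 to compound 3 is isobutyl in place of sec-butyl on a saturated chain carbon bound to an oxygen next to a carbonyl group. That change gave a 1.1-fold lower number from compound 1 to compound 3 (0.03 log units; within the scatter).

The same change, word for word in its place, separates compound 2 from compound 4: isobutyl in place of sec-butyl on a saturated chain carbon bound to an oxygen next to a carbonyl group. Because the earlier step of a 1.1-fold lower number from compound 1 to compound 3 (0.03 log units; within the scatter) stayed within the scatter, the expectation for compound 4 is a step of about a 1.1-fold lower number from compound 2 to compound 4 (0.04 log units; within the scatter) in this assay, meaning essentially no movement from compound 2. Compound 4 is therefore estimated at 340 ug/mL, with a likely range from 200 ug/mL to 600 ug/mL. This expectation rests only on a single measured pair, compound 1 and compound 3, and on the value of compound 2, so it is held loosely.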

Compound 4, half-maximal inhibitory concentration: 370 ug/mL
Beside the measured number, compound 4's estimate is 1.1-fold (0.04 log units) below it, within the range that was stated.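

On the core of compound 2, isobutyl in place of sec-butyl gives no change at the digits printed from compound 2 to compound 4 (within the scatter) in this assay. Set beside the step on the core of compound 1, the change carries from one core to the other with no difference that can be told apart: the same change on two cores in this assay, a 1.1-fold lower number (0.03 log units; within the scatter) from compound 1 to compound 3 and no change at the digits printed (within the scatter) from compound 2 to compound 4, 1.1-fold (0.03 log units) apart, within the scatter of two such steps. This shows that the swap leaves the number in this one cell assay in place on both cores, but a step that stays within the scatter on both is only a weak test of transfer, so it does not show that the two cores would answer alike to a change that does move the number, and two pairs make no general rule for the series.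

The compounds shown keep the carbamate side chain to two branched chains, so it stays open whether a longer chain, a benzyl group or a chain carrying an amine would move the number on either core. As far as these compounds go, it also stays open how these side chains would behave on a core with a methyl ether or an acetate ester in place of the hydroxyl groups of compound 2.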